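A larger chloroalkyl group on the amide carbonyl

The source may hold more compounds than are shown below. What is called first, only, known or untested is meant among the compounds shown, and "the series" means these compounds.

Compound 1 `C=C(C)C(=O)Nc1cccc(-c2nc3ccccc3s2)c1`: > 25000 nM
Compound 2 `O=C(CCl)Nc1cccc(-c2nc3ccccc3s2)c1`: 16000 nM

In an ADME assay on HepG2 cells (Homo sapiens) for inhibition, with a stated time of 72 h (a higher number here means that more compound is needed for the effect, a lower number that less compound is needed), compound 1 shows > 25000 nM, which is a limit of the assay and not a number (the limit of > 25000 nM in this assay, at which 1 of the 2 values shown sits). Compound 2 gives 16000 nM in this assay, and that is the only number shown. Among the compounds with values here, the single measured step reads an at least 1.5-fold lower number from compound 1 to compound 2 (0.19 log units; that floor lies within the scatter). Compound 3 `CC(C)(CCl)C(=O)Nc1cccc(-c2nc3ccccc3s2)c1` has not yet been measured; it differs from compound 2 by 1-(chloromethyl)-1-methylethyl in place of chloromethyl on a carbonyl carbon. Within the data shown here, no measured step swaps these two groups, so the measured step bears on it only loosely, and it was itself no larger than the scatter. Compound 3 is therefore expected to show no gain and more likely a weaker effect in this assay, with an estimated step of a 1.6-fold higher number from compound 2 to compound 3 (0.19 log units; within the scatter). The expected value for compound 3 is 25000 nM, within a range of 10000 nM to 80000 nM.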

Compound 3, half-maximal effective concentration: > 25000 nM
Compound 3: no number, only a limit; the forecaster's own chance of this, stated with the estimate: 55%; the middle value lies on the limit itself.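

In this assay compound 3 gives > 25000 nM, which is a limit of the assay and not a number. Placing 1-(chloromethyl)-1-methylethyl in place of chloromethyl on the carbonyl carbon gives an at least 1.5-fold higher number from compound 2 to compound 3 (0.19 log units; that floor lies within the scatter), so the larger chloroalkyl group brings no gain at this position, although the readable part of the step does not clear the scatter. The step between compound 1 and compound 3 cannot be read, and compound 2 remains the only compound with a number, so the comparison at this position rests mostly on a limit: the limit of > 25000 nM in this assay, at which 2 of the 3 values shown sit.

From the compounds shown here alone, how far compound 3 lies past its limit stays open. So does whether a bromomethyl group or a longer unbranched chain on the same carbonyl carbon would match compound 2.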